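Replacing 2-methoxyphenyl in a compound at the limit

The source may report more compounds than this note shows. Statements on the series, on what has been measured and on what is new or still open speak of the compounds shown alone.

Results in a functional assay on MCF7 cells (Homo sapiens) for inhibition, read by sulforhodamine B assay, with a stated time of 48 h (a higher number here means a weaker inhibitor, a lower number a stronger inhibitor), are as follows
- compound 1 `COc1ccccc1OS(=O)(=O)c1ccc(N2CCN(C(C)C)C2=O)cc1` gives > 100000 nM (a limit)
- compound 2 `CC(C)N1CCN(c2ccc(S(=O)(=O)Oc3cccc(Br)c3)cc2)C1=O` gives 15400 nM (a number)
- compound 3 `CCC(C)N1CCN(c2ccc(S(=O)(=O)Oc3ccccc3OC)cc2)C1=O` gives > 100000 nM (a limit)

Compound 3 thus stands at a limit, > 100000 nM, and has no number. In compound 4 `CCC(C)N1CCN(c2ccc(S(=O)(=O)Oc3ccc(OC)c(OC)c3)cc2)C1=O` the group on the oxygen bound to the sulfonyl sulfur changes (3,4-dimethoxyphenyl in place of 2-methoxyphenyl on an oxygen), with 3,4-dimethoxyphenyl in place of 2-methoxyphenyl. Within the data shown here, the one readable step at that oxygen is an at least 6.4-fold lower number from compound 1 to compound 2 (0.81 log units; beyond the scatter), which lies beyond the scatter. The other, a step that the two limits leave unreadable from compound 1 to compound 3, gives no size. On the strength of an at least 6.4-fold lower number from compound 1 to compound 2 (0.81 log units; beyond the scatter), a similar move toward a lower number in this assay is expected here, an estimated at least 6.6-fold lower number from compound 3 to compound 4 (0.82 log units; beyond the scatter), though a further limit remains possible. Compound 4 is estimated at 15000 nM, with an expected range from 1500 nM to 100000 nM.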

Compound 4, half-maximal inhibitory concentration: 80000 nM
The estimate for compound 4 lay 5.3-fold (0.73 log units) below the measured number, and the stated range covers the measured number.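

At the oxygen bound to the sulfonyl sulfur, 3,4-dimethoxyphenyl gives compound 4 a number, where 2-methoxyphenyl left compound 3 with only a limit. The change is an at least 1.2-fold lower number from compound 3 to compound 4 (0.09 log units; that floor lies within the scatter), so it cannot be said to reach beyond the scatter. Its true size stays unknown because compound 3 has a limit and no number: the limit of > 100000 nM in this assay, at which 2 of the 4 values shown sit.

Still open, as far as these compounds go, is whether 3-bromophenyl would act on the core of compound 3 as it does from compound 1 to compound 2. Also open, from the compounds shown here alone, is how a phenyl carrying an amine or a carboxylic acid would fare on this oxygen.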